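Saturated amide side chains around the shared core

The compounds below may be only part of what the source reports. "The series", "measured", "known", "first", "only" and "open" are said of these compounds alone.

The series holds the shared core of compound 1 `O=C(Nc1cc(-c2ccccc2)nn1-c1ccccc1)C1=CCCCC1`, where the carbonyl carbon carries a cyclohex-1-en-1-yl group. In a functional assay on cells for positive allosteric modulation of metabotropic glutamate receptor 5 (Rattus norvegicus), read by calcium flux (a lower number here means that less compound is needed, a higher number that more compound is needed for the effect), compound 1 gives 3300 nM. Compound 2 `O=C(Nc1cc(-c2ccccc2)nn1-c1ccccc1)C1CCCCC1` differs only at that carbonyl carbon. In this assay compound 2 gives > 10000 nM, which is a limit of the assay and not a number. Compound 2 therefore sits at the limit of > 10000 nM in this assay, at which 1 of the 2 values shown sits, and the change gave an at least 3.0-fold higher number from compound 1 to compound 2 (0.48 log units; beyond the scatter). Compound 3 `O=C(CC1CCCC1)Nc1cc(-c2ccccc2)nn1-c1ccccc1` is not yet measured; the change from compound 2 is cyclopentylmethyl in place of cyclohexyl on a carbonyl carbon, so the carbonyl again carries a saturated carbocyclic group. Among the measured compounds shown here, the one measured step bears on it only loosely: it shows that the saturated cyclohexyl of compound 2 reaches the limit, and no measured step separates two saturated groups. For compound 3 the expected step is a step that the limit leaves unreadable from compound 2 to compound 3, none beyond the scatter. The estimate for compound 3 in this assay is 15000 nM, within 5000 nM to 50000 nM.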

Compound 3, half-maximal effective concentration: 350 nM
Beside the measured number, compound 3's estimate is 43-fold (1.63 log units) above it; the measured number lies below the stated range.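

Cyclopentylmethyl and cyclohexyl have the same atoms, joined differently, yet on this carbonyl carbon they are far from interchangeable: in this assay the change gives an at least 28-fold lower number from compound 2 to compound 3 (1.45 log units; beyond the scatter). Compound 2 stands at a limit of the assay, which is not a number: the limit of > 10000 nM in this assay, at which 1 of the 3 values shown sits. Saturation alone does not set the result, as compound 2 falls on the weaker side of the unsaturated compound 1 while compound 3 goes against that trend, with a 9.4-fold lower number from compound 1 to compound 3 (0.97 log units; beyond the scatter).

The compounds shown do not tell whether the step belongs to the five-membered ring or to the way the ring is attached to the carbonyl carbon. Cyclopentyl and cyclohexylmethyl on the same carbonyl carbon would separate these two readings, and 2-cyclopentylethyl would test a longer chain.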